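The source may report more compounds than this note shows. Statements on the series, on what has been measured and on what is new or still open speak of the compounds shown alone.

Of the compounds shown here, three with the same core have been tested in an assay for inhibition of acid-sensing ion channel 3 (Homo sapiens), read by patch clamp, tested at 20 uM; a lower number here means less inhibition, a higher number more inhibition at the concentration tested (going by the name of the read-out). Compound 1 `NC(N)=NC(=O)c1nc(Cl)c(NCc2ccc(Cl)cc2)nc1N` gives 97%, compound 2 `CCCNc1nc(N)c(C(=O)N=C(N)N)nc1Cl` gives 91%, and compound 3 `NC(N)=NC(=O)c1nc(Cl)c(NCc2cccc(F)c2)nc1N` gives 90%. Compound 2 stands second highest of these three numbers, yet every step to its neighbours is within the scatter: a number 6 percentage points lower from compound 1 to compound 2 (within the scatter) and a number 1 percentage points lower from compound 2 to compound 3 (within the scatter), as is a number 7 percentage points lower from compound 1 to compound 3 (within the scatter). Exchanging ethyl, 4-chlorophenyl and 3-fluorophenyl on the saturated chain carbon bound to the ring nitrogen has thus made no difference that the measurement can resolve.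

Compound 4 `NC(N)=NC(=O)c1nc(Cl)c(NC2CC2)nc1N` is not yet measured. It differs from compound 2 in one place: cyclopropyl in place of propyl on a nitrogen on an aromatic ring. Among the compounds with values here, no measured step matches this exact exchange, but the three measured steps, each within the scatter, concern the same nitrogen, and the numbers across those exchanges are level within the scatter. The expected step of a number 3 percentage points lower from compound 2 to compound 4 (within the scatter) is therefore none beyond the scatter. Compound 4 is estimated to give 88% in this assay, with a range from 74% to 97%.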

Compound 4, a percentage reported as inhibition, at one concentration (the size of the read-out at that concentration, not a potency): 78%
Estimate against measurement, compound 4: 10 percentage points above, within the range that was stated.
By their numbers in this assay, from the lowest: compound 4; then compounds 3, 2 and 1 (each within the scatter of the next).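

In this assay, within the data shown here, a number 13 percentage points lower from compound 2 to compound 4 (beyond the scatter) is the first step at this nitrogen that the measurement can resolve, although it is modest, so this position does not accept every small group equally. Propyl and cyclopropyl have the same count of heavy atoms, all carbon, and neither has hydrogen-bond donors or acceptors; the count differs only in the three-membered ring, so tying the same carbons into that ring is enough to give a visible change. Nothing available here explains the lower number.

Going by these compounds, whether a larger ring such as cyclobutyl or cyclohexyl on this nitrogen would stay level with propyl or fall as cyclopropyl does remains open, as does the effect of a plain amino group with no carbon chain at all. On these data alone, all these numbers come from a single concentration, so how the compounds compare in potency also remains open.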